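Chain extension on the unsaturated amide of compound 2

A few compounds are considered here, and "the series" means these few. Any claim that something is new, unique, unknown or untested is made for them only; others in the source may bear on it.

Measured so far in a functional assay on A549 cells (Homo sapiens) for antiproliferative activity, read by MTT assay, with a stated time of 72 h; a higher number here means a weaker inhibitor, a lower number a stronger inhibitor:
- compound 1 `COc1cc(N(C)CCN(C)C)c(NC(=O)C(Cl)=C(Cl)Cl)cc1Nc1nccc(-c2cn(C)c3ccccc23)n1`: only a limit, > 50000 nM
- compound 2 `CC/C=C\C(=O)Nc1cc(Nc2nccc(-c3cn(C)c4ccccc34)n2)c(OC)cc1N(C)CCN(C)C`: 1530 nM

Within the data shown here, compound 2 gives the only actual number in this assay. Compound 1 sits at the limit of > 50000 nM in this assay, at which 1 of the 2 values shown sits, and its value is a limit, not a number. Among the measured compounds shown here, the single measured step, an at least 32-fold lower number from compound 1 to compound 2 (1.51 log units; beyond the scatter), swaps the whole group on the carbonyl carbon and is large.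

Compound 3 `CCC/C=C\C(=O)Nc1cc(Nc2nccc(-c3cn(C)c4ccccc34)n2)c(OC)cc1N(C)CCN(C)C` is to be measured; it differs from compound 2 by methyl in place of hydrogen on a saturated chain carbon, two bonds along the chain from a double-bonded chain carbon. For the measured compounds named here, no measured step in this assay changes the saturated part of the chain, so nothing here speaks for a shift beyond the scatter. The expected step is a 1.0-fold lower number from compound 2 to compound 3 (0.01 log units; within the scatter). Compound 3 is estimated at 1500 nM, within 600 nM to 4000 nM.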

Compound 3, half-maximal inhibitory concentration: 808 nM
Compound 3: the middle estimate sits 1.9-fold (0.27 log units) above what was measured; the range from low to high includes it.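

In this assay, methyl in place of hydrogen on this saturated chain carbon, two bonds along the chain from a double-bonded chain carbon, gives a 1.9-fold lower number from compound 2 to compound 3 (0.28 log units; within the scatter) and so shows no change that can be told from the scatter. Pent-1-en-1-yl in place of 1,2,2-trichloroethenyl on the carbonyl carbon gives a large step (an at least 61-fold lower number from compound 1 to compound 3 (1.79 log units; beyond the scatter)), much as but-1-en-1-yl did. Compound 1 remains a limit, not a number: the limit of > 50000 nM in this assay, at which 1 of the 3 values shown sits.

Open, going by these compounds, is whether a longer chain, such as hex-1-en-1-yl, moves the number beyond the scatter. Also open, on these data alone, is how a terminal amine on the same chain would read.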